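Ethoxycarbonyl to carboxy across two pairs of one series

A few compounds are considered here, and "the series" means these few. Any claim that something is new, unique, unknown or untested is made for them only; others in the source may bear on it.

Measured so far:
compound 1 `CCOC(=O)c1cc(-c2cc(OC)c(OC)c(OC)c2)c(-c2cccc(Br)c2)s1` — > 100000 nM
compound 2 `COc1cc(-c2cc(C(=O)O)sc2-c2cccc(Br)c2)cc(OC)c1OC` — > 100000 nM
compound 3 `CCOC(=O)c1cc(-c2ccc(OC)cc2)c(-c2cc(OC)c(OC)c(OC)c2)s1` — 7630 nM

In a functional assay on HT-1080 cells (Homo sapiens) for antiproliferative activity, read by MTT assay, with a stated time of 72 h (on this read-out higher numbers stand for weaker inhibition and lower numbers for stronger inhibition), compound 1 gives > 100000 nM, which is a limit of the assay and not a number. Compound 2 in this assay likewise gives > 100000 nM, again a limit. For the measured compounds named here, compound 3 is the only compound with a number in this assay, at 7630 nM. The change from compound 1 to compound 2 is hydrogen in place of ethyl on an oxygen next to a carbonyl group; the two limits leave the step that the two limits leave unreadable from compound 1 to compound 2. How the core of compound 1 differs from that of compound 3 is not broken down here.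

Compound 4 `COc1ccc(-c2cc(C(=O)O)sc2-c2cc(OC)c(OC)c(OC)c2)cc1`, not yet measured, differs from compound 3 by hydrogen in place of ethyl on an oxygen next to a carbonyl group, the same change at the same place. A loss is expected, a 7.9-fold higher number from compound 3 to compound 4 (0.90 log units; beyond the scatter), which rests on compound 1 and compound 2 both sitting at the limit of > 100000 nM in this assay, at which 2 of the 3 values shown sit, so the measured pair shows no sign of a gain from this change. Compound 4 is expected at 60000 nM, with a range from 15000 nM to 300000 nM.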

Compound 4, half-maximal inhibitory concentration: 5810 nM
For compound 4 the middle estimate is 10-fold (1.01 log units) above the measured one; measured number outside the range, below it.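

In this assay, the change from ethoxycarbonyl to carboxy on the core of compound 3 gives a 1.3-fold lower number from compound 3 to compound 4 (0.12 log units; within the scatter), so on this core the change leaves the read-out within the scatter. For the compounds shown here, the step on the core of compound 1 cannot be read, and both of its values are limits of the assay, not numbers: the limit of > 100000 nM in this assay, at which 2 of the 4 values shown sit. With only one readable step, the series does not show whether the change behaves alike on the two cores, so no size can be carried from one core to the other.

Open, from the compounds shown here alone, is how a primary amide or a longer ester chain at the same place would read on either core. Also open, going by these compounds, is whether any group there gives the core of compound 1 a number.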